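From compound 1 to compound 4: a methoxy step

The compounds below may be only part of what the source reports. "The series", "measured", "known", "first", "only" and "open" are said of these compounds alone.

Measured so far in a functional assay on 786-0 cells (Homo sapiens) for inhibition, read by sulforhodamine B assay, with a stated time of 48 h; on this read-out higher numbers stand for weaker inhibition of growth and lower numbers for stronger inhibition of growth:
- compound 1 `S=C(N/N=C/c1cccs1)Nc1ccccc1` gives 50400 nM
- compound 2 `S=C(N/N=C/c1cccs1)Nc1cccnc1` gives 5600 nM
- compound 3 `S=C(N/N=C/c1cccs1)Nc1cccc2ccccc12` gives 15200 nM

Among these three, compound 1 stands highest in this assay and so shows the weakest inhibition of growth. Its value of 50400 nM lies beyond the scatter from both of the others. Compound 3 comes closer at 15200 nM and compound 2 lies furthest off at 5600 nM on the same scale.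

Compound 4 `COc1ccc(NC(=S)N/N=C/c2cccs2)cc1` has not yet been measured. It keeps the core of compound 1 and changes in one place: methoxy in place of hydrogen on an aromatic carbon. Among the compounds with values here, no pair of measured compounds differs by a single change of this kind, so the data offer no direct guide to its size. The only support is indirect: compound 1 sits at the top of the range, and both compound 3 at 15200 nM and compound 2 at 5600 nM lie lower. A move towards a lower number therefore seems more likely than a move upwards, though a result within the scatter would not surprise. The expected change is a 2.1-fold lower number from compound 1 to compound 4 (0.32 log units; beyond the scatter) and it is estimated to be modest. For compound 4 the estimate is 24000 nM, with an expected range from 8000 nM to 70000 nM in this measurement.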

Compound 4, concentration for 50% growth inhibition: > 100000 nM
Compound 4: a limit, no number (the forecaster's own chance of this, stated with the estimate: 10%); middle value at least 4.1-fold (0.61 log units) from the limit.
By their numbers in this assay, from the lowest: compound 2; then compound 3; then compound 1. At a limit, above all of these: compound 4.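

Compound 4 in this assay yields only a limit and not a number: the limit of > 100000 nM in this assay, at which 1 of the 4 values shown sits. Methoxy in place of hydrogen on an aromatic carbon, para to a large group, gives an at least 1.9-fold higher number from compound 1 to compound 4 (0.29 log units; that floor lies within the scatter). Within the data shown here, the earlier compounds offered no step of any kind, so this is the first single change that can be read; it points towards weaker inhibition of growth rather than stronger, although its floor lies within the scatter and the true size of the change remains unknown.

On these data alone, what stays open is whether this direction belongs to methoxy in particular or would hold for other groups on the same aromatic carbon, such as a hydroxy group, an amine, a fluorine atom or a carboxylic acid. As far as these compounds go, it is equally open whether methoxy would behave in the same way elsewhere on that ring, and whether a longer alkoxy chain at this place would give a measurable number rather than a limit.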